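This account rests on a few compounds, and the source may have more. Where it says the series, first, only, none or still open, it means among the compounds named here.

Measured compounds in an assay on isolated protein for agonist activity at Free fatty acid receptor 1 (Homo sapiens); a higher number here means that more compound is needed for the effect, a lower number that less compound is needed:
Compound 1 `CC#CC(CC(=O)O)c1ccc(OCc2ccc3nc(-c4ccc(C(C)C)cc4)cn3c2)cc1`: 528 nM
Compound 2 `CC#CC(CC(=O)O)c1ccc(OCc2ccc3nc(-c4ccc(CC)cc4)cn3c2)cc1`: 496 nM
Compound 3 `CC#CC(CC(=O)O)c1ccc(OCc2ccc3nc(-c4ccc(C)cc4C)cn3c2)cc1`: 316 nM

On these numbers compound 3 gives the smallest figure, but it is not separated from the others: the steps of a 1.7-fold lower number from compound 1 to compound 3 (0.22 log units; within the scatter) and a 1.6-fold lower number from compound 2 to compound 3 (0.20 log units; within the scatter) both lie within the scatter, as does a 1.1-fold lower number from compound 1 to compound 2 (0.03 log units; within the scatter). All three compounds therefore sit together in this assay.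

Compound 4 `CC#CC(CC(=O)O)c1ccc(OCc2ccc3nc(-c4ccc(C)cc4)cn3c2)cc1` differs from compound 3 by hydrogen in place of methyl on an aromatic carbon. Among the compounds with values here, no measured step removes a methyl from this ring position alone. The nearest comparisons are the removal of a methyl on a saturated chain carbon, a 1.1-fold lower number from compound 1 to compound 2 (0.03 log units; within the scatter), and the two exchanges of the whole ring substitution pattern, a 1.7-fold lower number from compound 1 to compound 3 (0.22 log units; within the scatter) and a 1.6-fold lower number from compound 2 to compound 3 (0.20 log units; within the scatter), none of which moved the number beyond the scatter. A step of no more than the scatter is therefore expected here, in no fixed direction.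

Compound 4 is estimated at 400 nM in this assay, with a range from 200 nM to 800 nM. The expected step is a 1.3-fold higher number from compound 3 to compound 4 (0.10 log units; within the scatter).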

Compound 4, half-maximal effective concentration: 507 nM
Compound 4: the middle estimate sits 1.3-fold (0.10 log units) below what was measured, and the stated range covers the measured number.
By their numbers in this assay, from the lowest: compounds 3, 2, 4 and 1 (each within the scatter of the next).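

In this assay, within the data shown here, the exchange of 2,4-dimethylphenyl for 4-methylphenyl gives the first reading of this aromatic carbon, ortho to a large group, on its own: a 1.6-fold higher number from compound 3 to compound 4 (0.21 log units; within the scatter), so methyl and hydrogen are not separated here. The new compound also links the series at the other substituent, with a 1.0-fold higher number from compound 2 to compound 4 (0.01 log units; within the scatter) and a 1.0-fold lower number from compound 1 to compound 4 (0.02 log units; within the scatter), so 4-methylphenyl, 4-ethylphenyl and 4-isopropylphenyl all sit together. No other kind of measurement accompanies these numbers.

Still open, going by these compounds, is whether a methoxy group or a chlorine on this aromatic carbon would give a step beyond the scatter. Also open, on these data alone, is whether an amine or a longer chain in place of the remaining methyl would do so.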